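A few compounds are considered here, and "the series" means these few. Any claim that something is new, unique, unknown or untested is made for them only; others in the source may bear on it.

For the measured compounds named here, compound 2 `CCN(CC)S(=O)(=O)c1ccc(S(=O)(=O)N2CCC[C@@H](C(=O)N3CCC(F)(F)CC3)C2)cc1` gives 16 nM in a functional assay on MIA PaCa-2 cells (Homo sapiens) for inhibition, read by MTT assay, with a stated time of 7 days (on this read-out higher numbers stand for weaker inhibition and lower numbers for stronger inhibition), the lowest of the two numbers measured so far. Compound 1 `CCN(CC)S(=O)(=O)c1ccc(S(=O)(=O)N2CCC[C@@H](C(=O)NC3COC3)C2)cc1` gives 2340 nM in this assay. Going by the values given here, the single measured step, a 150-fold lower number from compound 1 to compound 2 (2.17 log units; beyond the scatter), also changed the group on the carbonyl carbon, so it bears on the present change, though it compared two other groups. Compound 3 `CCN(CC)S(=O)(=O)c1ccc(S(=O)(=O)N2CCC[C@@H](C(=O)N3CC[C@H](OC)C3)C2)cc1` differs from compound 2 in one place: 3-methoxypyrrolidin-1-yl in place of 4,4-difluoropiperidin-1-yl on a carbonyl carbon. A moderate rise in number is expected, a 3.1-fold higher number from compound 2 to compound 3 (0.49 log units; beyond the scatter), smaller than the measured step. Compound 3 is therefore estimated at 50 nM, within a range of 15 nM to 200 nM.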

Compound 3, half-maximal inhibitory concentration: 2460 nM
Compound 3: middle estimate off by 49-fold (1.69 log units), on the low side; the measured number lies above the stated range.
By their numbers in this assay, from the lowest: compound 2; then compounds 1 and 3 (each within the scatter of the next).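

The a 150-fold higher number from compound 2 to compound 3 (2.19 log units; beyond the scatter) shows that a low number at this carbonyl carbon does not extend to every ring amine joined there through its nitrogen. With a 1.1-fold higher number from compound 1 to compound 3 (0.02 log units; within the scatter), 3-methoxypyrrolidin-1-yl and (oxetan-3-yl)amino cannot be told apart, so among these three compounds only the 4,4-difluoropiperidin-1-yl of compound 2 gives the low number. No measured evidence here explains this gap. Still open, going by these compounds, is whether the low number goes with the fluorine atoms or the six-membered ring, which piperidin-1-yl without fluorine or 3,3-difluoropyrrolidin-1-yl would separate.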